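Trimming the piperazine substituent: from oxolane to cyclopropane

The source may report more compounds than this note shows. Statements on the series, on what has been measured and on what is new or still open speak of the compounds shown alone.

Measured so far:
compound 1, `N#Cc1cccc(COc2ccc(-c3cc(CN4CCN(c5ccc(C(F)(F)F)cn5)CC4)no3)cc2)c1`, 1700 nM
compound 2, `N#Cc1cccc(COc2ccc(-c3cc(CN4CCN(CC5CCCO5)CC4)no3)cc2)c1`, 4200 nM

Both compounds were tested in a functional assay on Huh-7 cells (Homo sapiens) for antiproliferative activity, read by sulforhodamine B assay, with a stated time of 72 h; a lower number here means a stronger inhibitor, a higher number a weaker inhibitor. Compound 2 gives 4200 nM, the higher of the two numbers, and so the weaker inhibitor of the pair. For the measured compounds named here, the only measured step, a 2.5-fold higher number from compound 1 to compound 2 (0.39 log units; beyond the scatter), exchanged an aromatic ring on the ring amine nitrogen for a chain carbon carrying a small saturated ring.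

Compound 3, `N#Cc1cccc(COc2ccc(-c3cc(CN4CCN(CC5CC5)CC4)no3)cc2)c1`, has not been measured. It differs from compound 2 as follows: cyclopropyl in place of oxolan-2-yl on a saturated chain carbon bound to an amine nitrogen in a ring. The step from compound 1 to compound 2 bears only loosely on this change, since here the saturated ring simply shrinks and loses its oxygen while the chain carbon on the nitrogen remains. Going by the values given here, no measured step covers such a change, so the expected step of a 1.2-fold higher number from compound 2 to compound 3 (0.08 log units; within the scatter) is small, possibly a slight loss of potency because compound 2 already sits at 4200 nM after losing the aromatic ring. Compound 3 is therefore estimated at 5000 nM in this assay, within a range of 2000 nM to 12000 nM.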

Compound 3, half-maximal inhibitory concentration: 2900 nM
Estimate against measurement, compound 3: 1.7-fold (0.24 log units) above, and the stated range covers the measured number.
By their numbers in this assay, from the lowest: compounds 1, 3 and 2 (each within the scatter of the next, the first and the last beyond it).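

In this assay, replacing the oxolan-2-yl on the saturated chain carbon with cyclopropyl removes the ring oxygen and shrinks the ring, yet the step is small, a 1.4-fold lower number from compound 2 to compound 3 (0.16 log units; within the scatter), so this change cannot be told apart from repeat-measurement noise. The comparison with the aromatic compound is new: the earlier step to the (oxolan-2-yl)methyl group lay beyond the scatter, whereas a 1.7-fold higher number from compound 1 to compound 3 (0.23 log units; within the scatter) does not, so a cyclopropylmethyl group on the ring amine nitrogen cannot be separated from the 5-(trifluoromethyl)pyridin-2-yl group, and compound 3 cannot be ranked against either neighbour. No measurement is available here that would explain these numbers.

On these data alone, the ring oxygen and the ring size change together in this step, so their separate contributions remain unknown; a cyclopentyl group, which keeps the five-membered ring but has carbon only, would pull them apart. As far as these compounds go, it also remains open how an open carbon chain such as isobutyl, or a cyclopropyl ring carrying an amine, would behave at this position on the saturated chain carbon.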